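Swapping the aryl group on the amide-type nitrogen

The source may report more compounds than this note shows. Statements on the series, on what has been measured and on what is new or still open speak of the compounds shown alone.

Measured so far:
Compound 1 `O=C(Nc1ccccc1[N+](=O)[O-])N[C@H]1CC[C@H](Oc2ccc(F)cc2)CC1` — in a functional assay on CRL2813 cells (Homo sapiens) for cytotoxicity, read by sulforhodamine B assay, with a stated time of 5 days (a higher number here means a weaker inhibitor, a lower number a stronger inhibitor), compound 1 gives 3500 nM.
Compound 2 `O=C(Nc1ccccc1OC(F)(F)F)N[C@H]1CC[C@H](Oc2ccc(F)cc2)CC1` — in this assay compound 2 gives only a limit, > 20000 nM.

Among the compounds with values here, compound 1 holds the only true number here; the other value is a limit. Within the data shown here, the one measured step, an at least 5.7-fold higher number from compound 1 to compound 2 (0.75 log units; beyond the scatter), is the replacement of the nitro group, and it costs potency, as far as the limit of > 20000 nM in this assay, at which 1 of the 2 values shown sits, allows one to see.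

Compound 3 `O=C(Nc1cccc(I)c1)N[C@H]1CC[C@H](Oc2ccc(F)cc2)CC1` also removes the nitro group, though in a different way: 3-iodophenyl in place of 2-nitrophenyl on an amide-type nitrogen. Among the measured compounds shown here, since the single measured step, an at least 5.7-fold higher number from compound 1 to compound 2 (0.75 log units; beyond the scatter), shows that removing the nitro weakens this series, compound 3 is expected to be weaker than compound 1 in this assay, with a real chance that it too reaches only a limit. The expected step is a 3.4-fold higher number from compound 1 to compound 3 (0.54 log units; beyond the scatter), and compound 3 is estimated at 12000 nM, within 4000 nM to 30000 nM.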

Compound 3, half-maximal inhibitory concentration: 5200 nM
Beside the measured number, compound 3's estimate is 2.3-fold (0.36 log units) above it, within the range that was stated.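

In this assay, the new result is a 1.5-fold higher number from compound 1 to compound 3 (0.17 log units; within the scatter), so the values for 2-nitrophenyl and 3-iodophenyl on the amide-type nitrogen lie within the scatter of each other. The nitro group is therefore not required for activity in this series, which the earlier step alone could not show. Compound 2 gives > 20000 nM, which is a limit and not a number: the limit of > 20000 nM in this assay, at which 1 of the 3 values shown sits.

The compounds shown do not separate the identity of the group from where it stands on the ring, as 2-nitrophenyl and 3-iodophenyl differ in both. They also leave open how an amine, a carboxylic acid or a plain phenyl would fare on the amide-type nitrogen.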